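The source may hold more compounds than are shown below. What is called first, only, known or untested is meant among the compounds shown, and "the series" means these compounds.

Measured so far in an ADME assay on microsomes from liver (Mus musculus) for metabolic stability; a higher number here means that the compound lasts longer, a lower number that the compound disappears faster:
- Compound 1 `NS(=O)(=O)CC(=O)NCCSc1nonc1/C(=N/O)Nc1ccc(F)c(C(F)F)c1`: 1.07 h
- Compound 2 `C[C@H](CSc1nonc1/C(=N/O)Nc1ccc(F)c(Br)c1)NC(=O)CS(N)(=O)=O`: 0.537 h

Within the data shown here, these are the only two measurements available. The structures of compound 1 and compound 2 differ in more than one place, so the pair isolates no single change. In this assay, compound 2 gives 0.537 h and compound 1 gives 1.07 h, and these two values lie within the usual scatter of each other.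

The next compound is compound 3 `C[C@@H](CSc1nonc1/C(=N/O)Nc1ccc(F)c(Br)c1)NC(=O)CS(N)(=O)=O`, which has not yet been measured. Its difference from compound 2 is purely one of configuration: the two compounds have the same atoms and bonds and differ only in configuration as drawn: 1 of 2 stereo elements differ; a stereocentre at a saturated chain carbon is drawn R in compound 2 and S in compound 3. Among the measured compounds shown here, no measured pair shows what a change of configuration does in this assay, so the data offer no basis for predicting a direction. The expectation therefore rests on compound 2, at 0.537 h, and on the identical atoms and bonds of the two structures. The expected step, a 1.0-fold higher number from compound 2 to compound 3 (0.01 log units; within the scatter), is not estimated to go beyond the scatter, although a real difference between the two configurations cannot be ruled out. For compound 3, the expected half-life is 0.55 h, with an estimated range from 0.25 h to 1.2 h.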

Compound 3, half-life: 0.398 h
Compound 3: middle estimate off by 1.4-fold (0.14 log units), on the high side; low and high end bracket the measured number.
By their numbers in this assay, from the lowest: compounds 3, 2 and 1 (each within the scatter of the next, the first and the last beyond it).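

In this assay, among these compounds, compound 2 and compound 3 give the first reading of a single change, the configuration at a saturated chain carbon, drawn R in compound 2 and S in compound 3, and the outcome is a 1.3-fold lower number from compound 2 to compound 3 (0.13 log units; within the scatter). Compound 1 and compound 2 differ in more than one place, so that earlier pair could not isolate any single change. At this stereocentre, the two configurations as drawn cannot be told apart in this assay, and any real gap between their numbers could have only one source: the fact that compounds 2 and 3 differ only in the configuration as drawn

The compounds shown leave open whether configuration at this carbon stays this silent when a larger group, such as an ethyl group or a longer chain, takes the place of the methyl group on the stereocentre. They also leave open whether the same holds with another end group on the chain, such as an amine or a carboxylic acid, or with the difluoromethyl group of compound 1 in place of the bromine shared by compound 2 and compound 3.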